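Mirror-Image Change at the Ring Carbon of Compound 2

The source may hold more compounds than are shown below. What is called first, only, known or untested is meant among the compounds shown, and "the series" means these compounds.

Measured compounds:
compound 1, `CC[C@@H]1c2cc(Cl)ccc2C(=O)N1c1cncc2c1CCC[C@H]2NC(C)=O`, 7 nM
compound 2, `CC(=O)N1CC[C@@H](Oc2cncc(N3C(=O)c4ccc(Cl)cc4C3(C)C)c2)C1`, 11 nM

In an assay on cells for inhibition of cytochrome P450 11B2, mitochondrial (Homo sapiens), read by HTRF (on this read-out lower numbers stand for stronger inhibition and higher numbers for weaker inhibition), compound 2 gives 11 nM, the higher of the two numbers shown; compound 1 gives 7 nM, and the gap between the two lies within the scatter, so neither can be called the stronger inhibitor.

Compound 3, `CC(=O)N1CC[C@H](Oc2cncc(N3C(=O)c4ccc(Cl)cc4C3(C)C)c2)C1`, differs from compound 2 in one way: the two compounds have the same atoms and bonds and differ only in configuration as drawn: 1 of 1 stereo elements differ; a stereocentre at a saturated ring carbon is drawn R in compound 2 and S in compound 3. Going by the values given here, no pair of compounds in this set differs only in configuration at one centre, so the data give no guide to how large such a step is. Mirror-image forms of one molecule frequently differ in how well they inhibit an enzyme, and the measured form may be the better one. Compound 3 is therefore expected to show a step of a 5.5-fold higher number from compound 2 to compound 3 (0.74 log units; beyond the scatter) in this assay, toward weaker inhibition, with wide uncertainty. The estimated value for compound 3 is 60 nM, within a range from 8 nM to 600 nM.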

Compound 3, half-maximal inhibitory concentration: 7 nM
The estimate for compound 3 lay 8.6-fold (0.93 log units) above the measured number; measured number outside the range, below it.
By their numbers in this assay, from the lowest: compounds 1, 3 and 2 (each within the scatter of the next).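

In this assay, the mirror-image change at the saturated ring carbon gives a 1.6-fold lower number from compound 2 to compound 3 (0.20 log units; within the scatter), so the R and S forms cannot be told apart on this read-out. Going by these compounds alone, this is the first pair in the set that tests a single stereocentre, and at this position the drawn configuration makes no difference larger than the ordinary spread of repeated measurements. Any real gap between the two would have to come from this one centre, and none can be seen: the fact that compounds 2 and 3 differ only in the configuration as drawn

This single pair cannot show whether the two forms would stay this close if the acetyl group gave way to an amine, a carboxylic acid or a longer chain. It also says nothing about how much the stereocentres drawn in compound 1 matter.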